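Diphenylmethylpiperazine series: heteroaryl swap at the chain end

The source may report more compounds than this note shows. Statements on the series, on what has been measured and on what is new or still open speak of the compounds shown alone.

Measured in an assay on RPMI-8226 cells for antagonist activity at P2X purinoceptor 7 (Homo sapiens), read by calcium flux; a lower number here means a stronger inhibitor, a higher number a weaker inhibitor:
compound 1 `O=c1[nH]c2ccccc2n1CCCN1CCN(S(=O)(=O)c2ccc([N+](=O)[O-])cc2)CC1`: > 10000 nM
compound 2 `O=c1[nH]c2ccccc2n1CCCN1CCC(=C(c2ccccc2)c2ccccc2)CC1`: 2400 nM
compound 3 `O=c1[nH]c2ccccc2n1CCCCN1CCN(C(c2ccccc2)c2ccccc2)CC1`: 180 nM

The value recorded for compound 1 is a limit of this assay, not a number (the limit of > 10000 nM in this assay, at which 1 of the 3 values shown sits). Of the two numbers in hand, compound 3 gives the lower one; the nearest, that of compound 2, lies above it by a gap well beyond the usual scatter. Among the compounds with values here, no two measured compounds differ in a single place, so no measured step can be drawn on here.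

Compound 4 `N#Cc1ccc2c(ccn2CCCCN2CCN(C(c3ccccc3)c3ccccc3)CC2)c1` keeps the four-carbon chain and the diphenylmethylpiperazine of compound 3 and differs from it only at the chain end: a group of 11 heavy atoms (9 carbon, 2 nitrogen; one five-membered aromatic ring with 1 hetero atom, one six-membered aromatic ring of carbon only) in place of a group of 10 heavy atoms (7 carbon, 2 nitrogen, 1 oxygen; one five-membered aromatic ring with 2 hetero atoms, one six-membered aromatic ring of carbon only), on a saturated chain carbon, four bonds along the chain from an amine nitrogen in a ring. Within the data shown here, with no measured step of this kind, the expectation rests on compound 3 alone and is held loosely. Compound 4 is expected to give 450 nM in this assay, within 120 nM to 1800 nM. The step of a 2.5-fold higher number from compound 3 to compound 4 (0.40 log units; beyond the scatter) is thus estimated as a modest weakening, not far beyond the scatter.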

Compound 4, half-maximal inhibitory concentration: 3800 nM
For compound 4 the middle estimate is 8.4-fold (0.93 log units) below the measured one; the whole stated range lies below it.
By their numbers in this assay, from the lowest: compound 3; then compounds 2 and 4 (each within the scatter of the next). At a limit, above all of these: compound 1.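

In this assay, the chain end proves a sensitive place in this series: with the rest of the structure held fixed, 5-cyano-1H-indol-1-yl in place of the group in compound 3 gives a 21-fold higher number from compound 3 to compound 4 (1.32 log units; beyond the scatter). Within the data shown here, this is the first step read across a single place, yet that place changes in several counted features at once: one hydrogen-bond donor goes, a triple bond comes in, and the five-membered ring keeps one hetero atom instead of two. No measured property at hand bears on this step, so it cannot be assigned to any one of these features.

Still open, going by these compounds, is whether a plain indol-1-yl group, or one carrying an amide or a carboxylic acid where the nitrile stands, tells the nitrile apart from the ring change. Also open, on these data alone, is how a longer chain behaves with either end group.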